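Replacing isoquinolin-3-yl with 6-methoxy-1,3-benzothiazol-2-yl: working notes

The compounds below may be only part of what the source reports. "The series", "measured", "known", "first", "only" and "open" are said of these compounds alone.

In a functional assay (blood) for inhibition, with Homo sapiens as the target (a higher number here means a weaker inhibitor, a lower number a stronger inhibitor), the three measured compounds all read as limits, not numbers:
Compound 1 (`CCCC(Oc1ccc2c(c1)c(SC(C)(C)C)c(CC(C)(C)C(=O)O)n2Cc1ccc(Cl)cc1)c1ccc2ccccc2n1`) gives a limit (> 3000 nM)
Compound 2 (`CC(C)(C)Sc1c(CC(C)(C)C(=O)O)n(Cc2ccc(Cl)cc2)c2ccc(OCc3cc4ccccc4cn3)cc12`) gives a limit (> 3000 nM)
Compound 3 (`CC(C)(C)Sc1c(CC(C)(C)C(=O)O)n(Cc2ccc(Cl)cc2)c2ccc(OCc3nc4cc(C(F)(F)F)ccc4s3)cc12`) gives a limit (> 3000 nM)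

Compound 2 therefore has no exact position in the series, only a limit (> 3000 nM). It shares that limit with every other measured compound (the limit of > 3000 nM in this assay, at which 3 of the 3 values shown sit).

Compound 4 (`COc1ccc2nc(COc3ccc4c(c3)c(SC(C)(C)C)c(CC(C)(C)C(=O)O)n4Cc3ccc(Cl)cc3)sc2c1`) carries 6-methoxy-1,3-benzothiazol-2-yl in place of isoquinolin-3-yl on a saturated chain carbon bound to an oxygen on an aromatic ring. Among the measured compounds shown here, no measured step is available to size this change, and the set contains no number to anchor it. The working expectation is therefore no shift beyond the scatter in either direction. The expected change, a number no higher from compound 2 to compound 4 (the limit leaves the size open) in this assay, reflects that view. For compound 4 the estimated value is 3000 nM with an expected range of 1000 nM to 6000 nM in this assay and a good chance of again reading only as a limit.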

Compound 4, half-maximal inhibitory concentration: 670 nM
The estimate for compound 4 lay 4.5-fold (0.65 log units) above the measured number, and the stated range ends above it.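

Compound 4 is the only compound shown that gives a number in this assay, so this position on the saturated chain carbon bound to an oxygen on an aromatic ring is the first shown to move the read-out off the shared limit: the limit of > 3000 nM in this assay, at which 3 of the 4 values shown sit. From the compounds shown here alone, replacing isoquinolin-3-yl with 6-methoxy-1,3-benzothiazol-2-yl gives an at least 4.4-fold lower number from compound 2 to compound 4 (0.65 log units; beyond the scatter), and the true size of that step stays open. Compound 3 also carries a 1,3-benzothiazol-2-yl group, with trifluoromethyl rather than methoxy, and its > 3000 nM is a limit, so that ring alone does not bring a number.

Going by these compounds, how much of the step belongs to methoxy and how much to the ring remains open. Also open, on these data alone, is how a hydroxy or dimethylamino group in place of methoxy would read in this assay.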